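The compounds below may be only part of what the source reports. "The series", "measured", "known", "first", "only" and "open" are said of these compounds alone.

Three compounds with a shared core have been examined in an ADME assay on Vero cells (Chlorocebus sabaeus) for cytotoxicity, read by MTT assay, with a stated time of 72 h; on this read-out higher numbers stand for lower toxicity in this test and lower numbers for higher toxicity in this test: compound 1 `O=C(c1ccccc1F)N1CCN(c2nc(=O)c3cc(C(F)(F)F)cc([N+](=O)[O-])c3s2)CC1`, compound 2 `O=C(c1ccc(Cl)cc1)N1CCN(c2nc(=O)c3cc(C(F)(F)F)cc([N+](=O)[O-])c3s2)CC1` and compound 3 `O=c1nc(N2CCN(CC3CCCCC3)CC2)sc2c([N+](=O)[O-])cc(C(F)(F)F)cc12`. Compound 1 gives > 125000 nM, which is a limit and not a number. Compound 2 gives > 125000 nM, again a limit. Compound 3 gives > 125000 nM, also a limit. Compound 3 therefore has no exact position of its own and stands with the other two at one shared mark: the limit of > 125000 nM in this assay, at which 3 of the 3 values shown sit.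

The next compound is compound 4 `Cc1ccc(C(=O)N2CCN(c3nc(=O)c4cc(C(F)(F)F)cc([N+](=O)[O-])c4s3)CC2)cc1`, and its difference from compound 3 is this: (4-methylphenyl)carbonyl in place of cyclohexylmethyl on an amine nitrogen in a ring. In words, (4-methylphenyl)carbonyl takes the place of cyclohexylmethyl on an amine nitrogen in a ring.

The closest precedents are a step that the two limits leave unreadable from compound 2 to compound 3 and a step that the two limits leave unreadable from compound 1 to compound 3, which exchange the same cyclohexylmethyl group and an arylcarbonyl group in the opposite sense. There is also a step that the two limits leave unreadable from compound 1 to compound 2, a change between two arylcarbonyl groups. For the measured compounds named here, none of these steps has a readable size, but no compound has yet come off the limit, so no step beyond the usual scatter is expected in this assay, in either direction.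

The expected change is a number no higher from compound 3 to compound 4 (the limit leaves the size open). The estimate for compound 4 is 125000 nM, with an expected range from 70000 nM to 250000 nM.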

Compound 4, half-maximal cytotoxic concentration: > 125000 nM
Compound 4 gave a limit, no number; the forecaster's own chance of this, stated with the estimate: 80%; the middle value lies on the limit itself.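

In this assay compound 4 gives > 125000 nM, which is a limit and not a number, and none of its steps from compound 1, compound 2 or compound 3 can be read. The four compounds share one mark: the limit of > 125000 nM in this assay, at which 4 of the 4 values shown sit. The compounds shown leave open how large any of these group changes is in this assay.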